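Adding a Chloro Group to Compound 2

A few compounds are considered here, and "the series" means these few. Any claim that something is new, unique, unknown or untested is made for them only; others in the source may bear on it.

Among the compounds with values here, compound 2 `CCNc1nc(C#Cc2ccccc2)nc2c1ncn2[C@H]1[C@H](O)[C@H](O)[C@@H]2C[C@@H]21` stands highest of the two numbers measured so far: in an assay on CHO cells for displacement of a labelled ligand from adenosine receptor A1 (Homo sapiens), read by scintillation counting, with a stated time of 60 min, tested at 10 uM (on this read-out lower numbers stand for less inhibition and higher numbers for more inhibition at the one concentration tested (going by the name of the read-out)), compound 2 gives 36%, while compound 1 `CNc1nc(C#Cc2ccccc2)nc2c1ncn2[C@H]1[C@H](O)[C@H](O)[C@@H]2C[C@@H]21` gives 18%. Within the data shown here, the only measured step, a number 18 percentage points higher from compound 1 to compound 2 (beyond the scatter), concerned methyl in place of hydrogen on a saturated chain carbon bound to a nitrogen on an aromatic ring, not the aromatic carbon changed here. Compound 3 `CCNc1nc(C#Cc2ccccc2Cl)nc2c1ncn2[C@H]1[C@H](O)[C@H](O)[C@@H]2C[C@@H]21` differs from compound 2 by chloro in place of hydrogen on an aromatic carbon. Among the measured compounds shown here, no measured step bears on this change, so for compound 3 a step no larger than the usual scatter is expected, a number 4 percentage points higher from compound 2 to compound 3 (within the scatter). Compound 3 is therefore estimated at 40%, with a likely range from 20% to 62%.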

Compound 3, a percentage reported as inhibition, at one concentration (the size of the read-out at that concentration, not a potency): 25%
Compound 3: middle estimate off by 15 percentage points, on the high side; the measured number falls inside the stated range.
By their numbers in this assay, from the lowest: compounds 1 and 3 (each within the scatter of the next); then compound 2.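

In this assay, the change from phenyl to 2-chlorophenyl gives a number 11 percentage points lower from compound 2 to compound 3 (beyond the scatter), so this aromatic carbon, ortho to a large group, is sensitive to the swap of a hydrogen for one chlorine atom. Within the data shown here, the direction here is downward, whereas the only earlier step, on the chain on the nitrogen, went upward. No available evidence explains the drop.

Still open, on these data alone, is whether methoxy or an amine on the same carbon would also lower the number, and whether chloro on another carbon of this ring would do the same.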